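Swapping an aromatic amide substituent for cyclohexylmethyl

The source may report more compounds than this note shows. Statements on the series, on what has been measured and on what is new or still open speak of the compounds shown alone.

Compound 2 `COc1cc(F)ccc1CNC(=O)c1cc2nc(C)c([C@H](OC(C)(C)C)C(=O)O)c(-c3cc(F)c4c(c3C)CCCO4)n2n1` is one of three close relatives that share a core and differ only in the group on a saturated chain carbon bound to an amide-type nitrogen. In an ADME assay on MT2 cells (Homo sapiens) for cytotoxicity (on this read-out lower numbers stand for higher toxicity in this test and higher numbers for lower toxicity in this test), compound 2 gives > 40000 nM, which is a limit of the assay rather than a number. Compound 1 `CCCc1cc(CNC(=O)c2cc3nc(C)c([C@H](OC(C)(C)C)C(=O)O)c(-c4cc(F)c5c(c4C)CCCO5)n3n2)ccc1F` carries a 4-fluoro-3-propylphenyl group at that place; in this assay compound 1 gives > 20000 nM, also a limit. Compound 3 `Cc1nc2cc(C(=O)NCCC(C)(C)C)nn2c(-c2cc(F)c3c(c2C)CCCO3)c1[C@H](OC(C)(C)C)C(=O)O` carries neopentyl there; in this assay compound 3 gives > 40000 nM, again a limit. Compound 2 thus sits at the limit of > 40000 nM in this assay, at which 2 of the 3 values shown sit, together with one relative, while the third sits at the limit of > 20000 nM in this assay, at which 1 of the 3 values shown sits. The steps between them, a step that the two limits leave unreadable from compound 1 to compound 2, a step that the two limits leave unreadable from compound 1 to compound 3 and a step that the two limits leave unreadable from compound 2 to compound 3, cannot be read: all three compounds are bounded by limits only.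

Compound 4 `Cc1nc2cc(C(=O)NCCC3CCCCC3)nn2c(-c2cc(F)c3c(c2C)CCCO3)c1[C@H](OC(C)(C)C)C(=O)O` differs from compound 2 in one place: cyclohexylmethyl in place of 4-fluoro-2-methoxyphenyl on a saturated chain carbon bound to an amide-type nitrogen. None of the measured steps is readable, so no direction or size can be drawn from them; the only pattern shown is that every measured compound reaches a limit, and none goes against it. Compound 4 is therefore expected to stay at a limit as well, with an estimated step of a number no higher from compound 2 to compound 4 (the limit leaves the size open). For compound 4 the estimated value is 40000 nM, between 20000 nM and 80000 nM.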

Compound 4, half-maximal cytotoxic concentration: > 40000 nM
Compound 4: no number, only a limit (the forecaster's own chance of this, stated with the estimate: 85%); the middle value lies on the limit itself.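

In this assay compound 4 gives only a limit, so the steps joining it to compound 1, compound 2 and compound 3 cannot be read, and compound 4 stands with compound 2 and compound 3: the limit of > 40000 nM in this assay, at which 3 of the 4 values shown sit.

The compounds shown leave open whether exchanging any of these groups changes the half-maximal cytotoxic concentration at all, and by how much.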